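Swapping a dimethylphenyl for a fluoro-nitrophenyl on the alkene

The source may report more compounds than this note shows. Statements on the series, on what has been measured and on what is new or still open speak of the compounds shown alone.

Of the compounds shown here, two have been measured in a functional assay on DU-145 cells (Homo sapiens) for inhibition, read by trypan blue exclusion, with a stated time of 96 h; a lower number here means a stronger inhibitor of growth, a higher number a weaker inhibitor of growth. Compound 1, `Cc1ccc(C)c(/C=C(\C(=O)c2ccc(Br)cc2)S(=O)(=O)Cc2ccc(F)cc2)c1`, gives 1000 nM. Compound 2, `O=C(/C(=C\c1ccc([N+](=O)[O-])c(O)c1)SCc1ccc(Br)cc1)c1ccc(C(F)(F)F)cc1`, gives 1000 nM, so compound 1 stands level with compound 2 within the usual scatter, and neither can be called the stronger growth inhibitor.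

Compound 3, `O=C(/C(=C\c1cc([N+](=O)[O-])ccc1F)S(=O)(=O)Cc1ccc(F)cc1)c1ccc(Br)cc1`, has not yet been measured. It is built from compound 1 by one change: 2-fluoro-5-nitrophenyl in place of 2,5-dimethylphenyl on a double-bonded chain carbon bound to a double-bonded chain carbon.

Among the measured compounds shown here, no step between two measured compounds matches this change, so nothing measured tells which way it should move the result. Compound 2 carries a quite different substituent pattern yet lands at the same value as compound 1, which argues that this part of the molecule is not the lever that moves potency here. The expected step of no change at the digits printed from compound 1 to compound 3 (within the scatter) is therefore small, no larger than the scatter. Compound 3 is estimated at 1000 nM, within a range of 400 nM to 2500 nM.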

Compound 3, concentration for 50% growth inhibition: > 100000 nM
Compound 3 was reported as a limit (the forecaster's own chance of this, stated with the estimate: 10%); at least 100-fold (2.00 log units) between middle value and limit.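

In this assay, the aryl group on the double-bonded chain carbon proves able to decide growth inhibition: 2-fluoro-5-nitrophenyl in place of 2,5-dimethylphenyl gives an at least 100-fold higher number from compound 1 to compound 3 (2.00 log units; beyond the scatter). Among the compounds shown here, with the rest of compound 1 left unchanged, this is the first single change that can be read, and it shows that this position is far from indifferent. The reading for compound 3 is a limit and not a number: the limit of > 100000 nM in this assay, at which 1 of the 3 values shown sits.

The compounds shown leave open whether the loss follows the fluoro group, the nitro group or the two together, since both enter in one step and both methyl groups leave in it. They also leave open how a ring carrying an amine in place of the nitro group would read.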